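The source may report more compounds than this note shows. Statements on the series, on what has been measured and on what is new or still open speak of the compounds shown alone.

Measured so far:

- compound 1 `CCC(CC)S(=O)(=O)c1ccc(S(=O)(=O)N2CCC[C@@H](C(=O)N3CCC(F)(F)CC3)C2)cc1`: in a functional assay on MIA PaCa-2 cells (Homo sapiens) for inhibition, read by MTT assay, with a stated time of 7 days (a lower number here means a stronger inhibitor, a higher number a weaker inhibitor), compound 1 gives 13 nM
- compound 2 `O=C([C@@H]1CCCN(S(=O)(=O)c2ccc(S(=O)(=O)N3CC[C@H](O)C3)cc2)C1)N1CCC(F)(F)CC1`: in this assay compound 2 gives 590 nM
- compound 3 `CCN(CC)S(=O)(=O)c1ccc(S(=O)(=O)N2CCC[C@@H](C(=O)N3CCOCC3)C2)cc1`: in this assay compound 3 gives 350 nM

Compound 3 stands second highest of the three numbers. Its nearest neighbour is compound 2, whose number is within the scatter of compound 3, so no order between compound 2 and compound 3 can be read. Among the compounds with values here, compound 1 lies well below compound 3, beyond the scatter, and is the only compound here whose steps to all others are beyond the scatter.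

The one step shown, a 45-fold higher number from compound 1 to compound 2 (1.66 log units; beyond the scatter), sits on a sulfonyl sulfur at the far end of the shared core and leaves the amide untouched. Within the data shown here, no measured pair differs at the carbonyl carbon alone: compound 1 and compound 3 carry different amides, but they also differ on the sulfonyl sulfur, so their two values show nothing separable about the amide.

Compound 4 `CCN(CC)S(=O)(=O)c1ccc(S(=O)(=O)N2CCC[C@@H](C(=O)NC3CCOCC3)C2)cc1` differs from compound 3 as follows: (oxan-4-yl)amino in place of morpholin-4-yl on a carbonyl carbon. Nothing measured bears on this change, so the expectation rests on compound 3 alone, with a wide range. The expected step in this assay is no change at the digits printed from compound 3 to compound 4 (within the scatter), in no direction beyond the scatter. Compound 4 is therefore estimated at 350 nM, within 100 nM to 1200 nM.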

Compound 4, half-maximal inhibitory concentration: 3770 nM
The estimate for compound 4 lay 11-fold (1.03 log units) below the measured number, and the stated range ends below it.
By their numbers in this assay, from the lowest: compound 1; then compounds 3 and 2 (each within the scatter of the next); then compound 4.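

In this assay, the carbonyl carbon proves a sensitive position: an 11-fold higher number from compound 3 to compound 4 (1.03 log units; beyond the scatter), with the rest of the molecule unchanged. Within the data shown here, this is the first pair that differs at this carbon alone, so the size of a change here can now be read on its own, and it is large. The entering (oxan-4-yl)amino carries a hydrogen-bond donor that morpholin-4-yl lacks, and its six-membered ring holds one hetero atom rather than two, but this single pair cannot separate these differences, and nothing at hand accounts for the step.

As far as these compounds go, whether the step follows the amide hydrogen or the ring remains open: a methyl(oxan-4-yl)amino group or a piperidin-1-yl group on the same carbonyl carbon would begin to separate the two. Among these compounds, also open is whether a step of this size would recur with other groups on the sulfonyl sulfur, such as the pentan-3-yl of compound 1, as the only reading at this position comes from a single pair.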